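Allylsulfanyl in place of methylsulfanyl on a limit-bound series

The source may report more compounds than this note shows. Statements on the series, on what has been measured and on what is new or still open speak of the compounds shown alone.

Compound 3 `CCCc1ncc2cnnc(SC)n12` carries a methylsulfanyl group on the shared core. In a functional assay for inhibition, with Homo sapiens as the target (a higher number here means a weaker inhibitor, a lower number a stronger inhibitor), compound 3 gives only a limit, > 48000 nM. Its hydroxy counterpart, compound 1 `CCCc1ncc2cnnc(O)n12`, likewise returns a limit in this assay, > 48000 nM. The step that the two limits leave unreadable from compound 1 to compound 3 cannot be read because the limit of > 48000 nM in this assay, at which 3 of the 3 values shown sit, holds both values. Compound 2 `C=CCSc1nncc2cnc(-c3ccccc3)n12`, which carries an allylsulfanyl group together with a phenyl group, also stops at a limit in this assay, > 48000 nM.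

Compound 4 `C=CCSc1nncc2cnc(CCC)n12` is the compound still to be measured. It differs from compound 3 by vinyl in place of hydrogen on a saturated chain carbon bound to a sulfur. For the measured compounds named here, no measured step tracks this change directly, and the one readable comparison, from compound 1 to compound 3, shows no size at all. Going by the values given here, every value so far sits at the same limit, and compound 2 already carries the allylsulfanyl group without leaving it. Compound 4 is therefore expected to stay at the limit as well. The expected step that the limit leaves unreadable from compound 3 to compound 4 is no movement beyond the scatter. For compound 4 in this assay the estimate is 80000 nM, with a range from 30000 nM to 300000 nM, and most likely the assay will again report only a limit.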

Compound 4, half-maximal inhibitory concentration: > 48000 nM
Compound 4 ended at the assay's limit (the forecaster's own chance of this, stated with the estimate: 85%); the middle value lies beyond the limit too.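

No step from compound 1, compound 2 or compound 3 to compound 4 can be read in this assay, because all four compounds stop at the same limit: the limit of > 48000 nM in this assay, at which 4 of the 4 values shown sit.

The compounds shown leave open how strongly any of them inhibits, and whether exchanging the groups on the shared core changes that at all.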